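The source may hold more compounds than are shown below. What is called first, only, known or untested is meant among the compounds shown, and "the series" means these compounds.

In a functional assay on HFF cells (Homo sapiens) for cytotoxicity (a lower number here means a stronger inhibitor, a higher number a weaker inhibitor), compound 3 `O[C@@H]1[C@@H](CBr)OC(n2c(Cl)nc3cc(Cl)c(Cl)cc32)[C@@H]1O` gives 32000 nM and stands level with its two measured neighbours. Compound 1 `COC[C@H]1OC(n2c(Cl)nc3cc(Cl)c(Cl)cc32)[C@H](O)[C@@H]1O` gives 32000 nM and compound 2 `CCCCOC[C@H]1OC(n2c(Cl)nc3cc(Cl)c(Cl)cc32)[C@H](O)[C@@H]1O` gives 32000 nM in the same read-out.

The next compound is compound 4 `CSC[C@H]1OC(n2c(Cl)nc3cc(Cl)c(Cl)cc32)[C@H](O)[C@@H]1O`, which has methylsulfanyl in place of bromo on a saturated chain carbon bound to a saturated ring carbon on the shared core.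

Among the measured compounds shown here, three measured steps bear on this change. Bromo in place of methoxy gave no change at the digits printed from compound 1 to compound 3 (within the scatter) and bromo in place of butoxy gave no change at the digits printed from compound 2 to compound 3 (within the scatter) at the same carbon. Propyl in place of hydrogen on the methoxy group gave no change at the digits printed from compound 1 to compound 2 (within the scatter) as well. For the measured compounds named here, all three steps are null, but no measured compound carries methylsulfanyl, so the expectation is an extrapolation from these three compounds.

No step beyond the scatter is expected, and the estimated outcome is no change at the digits printed from compound 3 to compound 4 (within the scatter) in either direction. Compound 4 is expected at 32000 nM with an estimated range from 14000 nM to 70000 nM in this assay for now.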

Compound 4, half-maximal inhibitory concentration: 32000 nM
Estimate against measurement, compound 4: no gap at the digits printed; measured number inside the range.
By their numbers in this assay, from the lowest: compounds 1, 2, 3 and 4 (each within the scatter of the next).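

Methylsulfanyl extends the tolerated set at this position to a group with sulfur as its linking atom: in this assay, putting it in place of bromo gives no change at the digits printed from compound 3 to compound 4 (within the scatter), in place of butoxy gives no change at the digits printed from compound 2 to compound 4 (within the scatter), and in place of methoxy gives no change at the digits printed from compound 1 to compound 4 (within the scatter). Methoxy, butoxy, bromo and methylsulfanyl on a saturated chain carbon bound to a saturated ring carbon therefore all read alike in this assay. No evidence is available on why these four compounds read alike.

Still open, as far as these compounds go, is whether an amine, a carboxylic acid or a longer chain on the sulfur would leave this read-out unmoved. The four compounds differ only at this one place, and they say nothing about changes elsewhere on the shared core.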